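Dimethylamino on the chain: expected effect in compound 4

This account rests on a few compounds, and the source may have more. Where it says the series, first, only, none or still open, it means among the compounds named here.

Measured so far:
Compound 1, `CCN(Cc1ccccc1)c1cccc(C(=O)N2CCc3ccc(OS(N)(=O)=O)cc3C2)c1`: 17.3%
Compound 2, `CN(C)CCN(Cc1ccccc1)c1cccc(C(=O)N2CCc3ccc(OS(N)(=O)=O)cc3C2)c1`: 0%
Compound 3, `CCCN(Cc1ccccc1)c1ccc(C(=O)N2CCc3ccc(OS(N)(=O)=O)cc3C2)cc1`: 64.8%

The three measured compounds were tested in an assay on HEK293 cells for inhibition of Steryl-sulfatase (Homo sapiens), tested at 0.1 uM; on this read-out higher numbers stand for a stronger effect at the one concentration tested and lower numbers for a weaker effect. Among them compound 3 gives the highest number, 64.8%, and its steps to compound 1 and to compound 2 both lie beyond the scatter. The difference between the core of compound 1 and the core of compound 3 is not broken down here.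

From compound 1 to compound 2 the change is dimethylamino in place of hydrogen on a saturated chain carbon, two bonds along the chain from a nitrogen on an aromatic ring, and this assay moved by a number 17.3 percentage points lower from compound 1 to compound 2 (beyond the scatter), a modest step beyond the scatter.

Compound 4, `CN(C)CCCN(Cc1ccccc1)c1ccc(C(=O)N2CCc3ccc(OS(N)(=O)=O)cc3C2)cc1`, is not yet measured. It differs from compound 3 by dimethylamino in place of hydrogen on a saturated chain carbon, three bonds along the chain from a nitrogen on an aromatic ring. This is the same kind of change as from compound 1 to compound 2, but not the same: there the dimethylamino enters two bonds along the chain from the nitrogen on the aromatic ring, here three bonds along the chain. Resting on compound 2 and its 0% against compound 1, a drop of similar or somewhat larger size is expected, a number 29.8 percentage points lower from compound 3 to compound 4 (beyond the scatter), so that compound 4 is estimated at 35%, between 10% and 60%.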

Compound 4, a percentage reported as inhibition, at one concentration (the size of the read-out at that concentration, not a potency) in the Steryl-sulfatase assay: 16.2%
Compound 4: middle estimate off by 18.8 percentage points, on the high side; the range from low to high includes it.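

In the Steryl-sulfatase assay the new step is a number 48.6 percentage points lower from compound 3 to compound 4 (beyond the scatter). In a physicochemical assay for lipophilicity (a higher number here means a more lipophilic compound, a lower number a more polar compound), compound 3 gives 1.93 and compound 4 gives 1.93, and the same step reads no change at the digits printed from compound 3 to compound 4 (within the scatter). Dimethylamino lowers the number in the Steryl-sulfatase assay on both cores, but the size of the step does not carry over from one core to the other: the same change on two cores in the Steryl-sulfatase assay, a number 17.3 percentage points lower (beyond the scatter) from compound 1 to compound 2 and a number 48.6 percentage points lower (beyond the scatter) from compound 3 to compound 4, 31.3 percentage points apart, beyond the scatter of two such steps. This supports the direction of the change in these two pairs only and does not separate the effect of the core from that of the placement, with dimethylamino two bonds along the chain in compound 2 and three bonds along the chain in compound 4.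

The compounds shown leave open whether dimethylamino at two bonds along the chain on the core of compound 3 would give a similar step. They also leave open whether a hydroxyl group, a carboxylic acid or a longer chain at that end would lower the number in the same way.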